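Swapping Chloro for Methoxy on a Shared Core

This account rests on a few compounds, and the source may have more. Where it says the series, first, only, none or still open, it means among the compounds named here.

Three compounds share one core and differ only in the group on one aromatic carbon. Compound 1 `Cc1ccc(-n2nc(-c3ccc(C(F)(F)F)cc3O)nc2-c2ccccc2O)cc1` carries methyl there, compound 2 `CC(C)(C)c1ccc(-n2nc(-c3ccc(C(F)(F)F)cc3O)nc2-c2ccccc2O)cc1` tert-butyl, and compound 3 `Oc1cc(C(F)(F)F)ccc1-c1nc(-c2ccccc2O)n(-c2ccc(Cl)cc2)n1` chloro. In a functional assay on PC-12 cells (Rattus norvegicus) for cytotoxicity, read by MTT assay, with stated times of 2 h and 24 h, tested at 1 uM (a higher number here means a stronger effect of the compound at the concentration tested, a lower number a weaker effect), compound 1 gives 71.5%, compound 2 gives 67.3%, and compound 3 gives 68%. Compound 3 stands second highest of these three numbers; its nearest neighbour is compound 2 and its furthest is compound 1, and both gaps are within the scatter, so the three read as alike.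

Compound 4 `COc1ccc(-n2nc(-c3ccc(C(F)(F)F)cc3O)nc2-c2ccccc2O)cc1` is the next step: methoxy in place of chloro on an aromatic carbon. The measured steps that bear on it are the earlier swaps at the same aromatic carbon: a number 4.2 percentage points lower from compound 1 to compound 2 (within the scatter), a number 3.5 percentage points lower from compound 1 to compound 3 (within the scatter), and a number 0.7 percentage points higher from compound 2 to compound 3 (within the scatter). Each of these left the read-out within the scatter, so the step in this assay from chloro to methoxy is expected to stay small as well: a number 1 percentage points higher from compound 3 to compound 4 (within the scatter). Methoxy is the first group in this set that brings a hydrogen-bond acceptor, and no measured step covers such a change, so the expected range is kept somewhat wide. Compound 4 is therefore estimated at 69%, with a range from 58% to 80%.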

Compound 4, a percentage reported as activity, at one concentration (the size of the read-out at that concentration, not a potency): 69%
Compound 4: middle estimate and measured number agree at the digits printed; the range from low to high includes it.
By their numbers in this assay, from the lowest: compounds 2, 3, 4 and 1 (each within the scatter of the next).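

Methoxy brings a hydrogen-bond acceptor to this aromatic carbon, para to a large group, where chloro brings none, and in this assay this swap gives a number 1 percentage points higher from compound 3 to compound 4 (within the scatter). The comparisons with the other two groups agree, with a number 1.7 percentage points higher from compound 2 to compound 4 (within the scatter) and a number 2.5 percentage points lower from compound 1 to compound 4 (within the scatter), so methyl, tert-butyl, chloro and methoxy all read as alike at this position. The 4-chlorophenyl to 4-methoxyphenyl change therefore adds a hydrogen-bond acceptor to the set without moving the read-out beyond the usual scatter, though nothing available here explains that outcome.

Still open, going by these compounds, is whether a group of a different kind at this carbon, such as an amine, a carboxylic acid or a longer chain, would also leave the read-out within the scatter of these four. On these data alone, because each number gives the size of the effect at one concentration and not a potency, it also remains open whether the four compounds would still read as alike at other concentrations.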